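The source may hold more compounds than are shown below. What is called first, only, known or untested is meant among the compounds shown, and "the series" means these compounds.

Measured compounds:
compound 1 `CCc1ccc(C(=O)NC[C@H]2c3[nH]c4ccccc4c3C[C@H]3[C@H]4c5[nH]c6ccccc6c5C[C@@H]([C@H](C#N)N23)N4C)cc1` — in a functional assay on MCF7 cells (Homo sapiens) for cytotoxicity, read by MTT assay, with a stated time of 72 h (on this read-out higher numbers stand for weaker inhibition and lower numbers for stronger inhibition), compound 1 gives 170 nM
compound 2 `CN1[C@@H]2c3[nH]c4ccccc4c3C[C@H]1[C@H](C#N)N1[C@@H](CNC(=O)c3cc4ccccc4s3)c3[nH]c4ccccc4c3C[C@@H]21` — in this assay compound 2 gives 3180 nM

Among the measured compounds shown here, compound 2 holds the higher of the two numbers; its only neighbour is compound 1, and the step between them is a 19-fold higher number from compound 1 to compound 2 (1.27 log units; beyond the scatter). Compound 3 `CN1[C@@H]2c3[nH]c4ccccc4c3C[C@H]1[C@H](C#N)N1[C@@H](CNC(=O)c3cc4ccccc4o3)c3[nH]c4ccccc4c3C[C@@H]21` is not yet measured. It differs from compound 2 by 1-benzofuran-2-yl in place of 1-benzothiophen-2-yl on a carbonyl carbon. For the measured compounds named here, the one measured step, a 19-fold higher number from compound 1 to compound 2 (1.27 log units; beyond the scatter), replaced a 4-ethylphenyl with a 1-benzothiophen-2-yl on the carbonyl carbon; it does not cover the exchange of the 1-benzothiophen-2-yl for a 1-benzofuran-2-yl, so no measured step bears directly on the change from compound 2 to compound 3. For compound 3 the expectation in this assay is accordingly a step of a 1.1-fold lower number from compound 2 to compound 3 (0.03 log units; within the scatter), nothing beyond the scatter, with wide uncertainty. Compound 3 is estimated at 3000 nM, in a range from 900 nM to 10000 nM.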

Compound 3, half-maximal inhibitory concentration: 320 nM
Beside the measured number, compound 3's estimate is 9.4-fold (0.97 log units) above it, and the stated range ends above it.
By their numbers in this assay, from the lowest: compounds 1 and 3 (each within the scatter of the next); then compound 2.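

In this assay, exchanging the single ring hetero atom, sulfur for oxygen, on this carbonyl carbon gives a 9.9-fold lower number from compound 2 to compound 3 (1.00 log units; beyond the scatter), so the position responds to 1-benzofuran-2-yl in place of 1-benzothiophen-2-yl and not only to the loss of 4-ethylphenyl. The step of a 1.9-fold higher number from compound 1 to compound 3 (0.27 log units; within the scatter) places 1-benzofuran-2-yl level with 4-ethylphenyl, and compound 3 therefore goes against reading the high number of compound 2 as a general result of a two-ring aromatic group at this place. Nothing available here accounts for the effect of the sulfur-to-oxygen exchange.

Open, on these data alone, is whether a 1H-indol-2-yl, with nitrogen as the ring hetero atom, would follow compound 3 or compound 2. Also open, as far as these compounds go, is whether a methoxy group or a chlorine on the six-membered ring of 1-benzofuran-2-yl would move the number.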